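This account rests on a few compounds, and the source may have more. Where it says the series, first, only, none or still open, it means among the compounds named here.

Working notes on the series. In a functional assay on MCF7 cells (Homo sapiens) for antiproliferative activity (a lower number here means a stronger inhibitor, a higher number a weaker inhibitor), compound 1 `CC(C)=CCc1cc(C(=O)Nc2cc3ccc(OCCC4CCCCN4)c(C)c3oc2=O)ccc1O` gives 710 nM, and compound 2 `CC(C)=CCc1cc(C(=O)Nc2cc3ccc(OCCCN(C)C(C)C)c(C)c3oc2=O)ccc1O` gives 1050 nM. Within the data shown here, these are the only two numbers available, and they do not separate compound 2 from compound 1.

Compound 3 `CC(C)=CCc1cc(C(=O)Nc2cc3ccc(OCCCN(C)C(C)(C)C)c(C)c3oc2=O)ccc1O` differs from compound 2 by one change, methyl in place of hydrogen on a saturated chain carbon bound to an amine nitrogen and two saturated chain carbons, which reads as isopropyl to tert-butyl. Among the measured compounds shown here, no measured compound carries the tert-butyl group, so no direct precedent exists for this change. The nearest guide is the placing of (isopropyl(methyl)amino)methyl in place of piperidin-2-yl, which is a 1.5-fold higher number from compound 1 to compound 2 (0.17 log units; within the scatter). With that single step so small, no step beyond the scatter is expected in this assay, although one step is thin support.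

The expected step is a 1.0-fold higher number from compound 2 to compound 3 (0.02 log units; within the scatter). For compound 3 the estimated value is 1100 nM, with an expected range of 550 nM to 2300 nM.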

Compound 3, half-maximal inhibitory concentration: 1140 nM
For compound 3 the middle estimate is 1.0-fold (0.02 log units) below the measured one, within the range that was stated.
By their numbers in this assay, from the lowest: compounds 1, 2 and 3 (each within the scatter of the next).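

In this assay, methyl in place of hydrogen on a saturated chain carbon bound to an amine nitrogen and two saturated chain carbons, which reads as isopropyl to tert-butyl, gives a 1.1-fold higher number from compound 2 to compound 3 (0.04 log units; within the scatter) and so adds a direct reading at this position: the added methyl leaves no change that can be told from the scatter. The comparison with the piperidin-2-yl group also gains a second open-chain partner, as (methyl(tert-butyl)amino)methyl in its place gives a 1.6-fold higher number from compound 1 to compound 3 (0.21 log units; within the scatter) and likewise does not separate from compound 1. Nothing available offers an explanation for these small steps.

Among these compounds, all three compounds carry an alkyl-substituted amine at this end of the chain, and no step among them leaves the scatter. As far as these compounds go, whether a primary amine, a morpholine ring or a carboxylic acid in place of that amine, or a longer chain between the aromatic oxygen and the nitrogen, would move the number in this assay remains open.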